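Removing the piperidinyl group from a pyrazole

This account rests on a few compounds, and the source may have more. Where it says the series, first, only, none or still open, it means among the compounds named here.

For the measured compounds named here, compound 3 `Cc1cc2c(c(N)nn2C)c(N2CCCCC2)n1` is one of three compounds measured in an assay on isolated protein for inhibition of ribosomal protein S6 kinase alpha-5 (Homo sapiens), read by mobility shift assay, tested at 30 uM; a higher number here means more inhibition at the concentration tested (going by the name of the read-out), a lower number less inhibition. Compound 3 gives 7% in this assay. Compound 1 `Cc1cc2[nH]nc(N)c2c(N2CCCCC2)n1` carries a hydrogen on the aromatic nitrogen where compound 3 carries a methyl. In this assay, going by the values given here, compound 1 gives 87%, and the step of a number 80 percentage points lower from compound 1 to compound 3 (beyond the scatter) is the only single-point change recorded here. Compound 2 `COc1ccc(-c2c(C)[nH]c(=O)c3c(N)nn(C)c23)cc1` gives 13%, a number that does not differ from compound 3 beyond the scatter, so compound 3 and compound 2 together sit at the low end of the measured set, far beneath compound 1.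

Compound 4 `Cc1cc2c(cn1)c(N)nn2C` differs from compound 3 in one place: hydrogen in place of piperidin-1-yl on an aromatic carbon. Among the compounds with values here, no measured pair shows what removing the piperidin-1-yl group does in this assay; the one recorded step concerns the aromatic nitrogen instead. Compound 3 already shows little inhibition, so there is almost no room for a further fall, and a rise would require the change to restore what the methyl on the aromatic nitrogen removed, which nothing measured supports. The step of a number 1 percentage points higher from compound 3 to compound 4 (within the scatter) is therefore expected to stay within the scatter. Compound 4 is estimated to give 8% in this assay, within a range of 0% to 30%.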

Compound 4, a percentage reported as inhibition, at one concentration (the size of the read-out at that concentration, not a potency): -2%
Beside the measured number, compound 4's estimate is 10 percentage points above it, and the stated range ends above it.
By their numbers in this assay, from the lowest: compounds 4, 3 and 2 (each within the scatter of the next, the first and the last beyond it); then compound 1.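

In this assay, for the compounds shown here, the step of a number 9 percentage points lower from compound 3 to compound 4 (within the scatter) gives the first reading on this aromatic carbon: with a methyl on the aromatic nitrogen, the piperidin-1-yl group can give way to hydrogen without a change beyond the scatter. The earlier compounds shown here spoke only to the aromatic nitrogen, and this new reading adds that the six-membered non-aromatic ring is not enough on its own to give marked inhibition once that methyl is present, although a reading taken where inhibition is already slight cannot show that the group has no effect in general. Nothing available here accounts for this outcome.

The compounds shown leave open what the same removal does when the aromatic nitrogen carries hydrogen, as in compound 1, which gives 87% and so has ample room for a fall. They also leave open whether a morpholine or a simple dimethylamino group on this aromatic carbon would behave as the piperidin-1-yl group does, with either hydrogen or methyl on the aromatic nitrogen.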